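Changing the Ester Side Chain: Compound 3 to Compound 4

A few compounds are considered here, and "the series" means these few. Any claim that something is new, unique, unknown or untested is made for them only; others in the source may bear on it.

Measured compounds:
compound 1, `COC(=O)C1=C(C)NC(C)=C(C(=O)OCCCl)C1c1cccc([N+](=O)[O-])c1`, 26 nM
compound 2, `COC(=O)C1=C(C)NC(C)=C(C(=O)OCC(F)(F)F)C1c1cccc([N+](=O)[O-])c1`, 16 nM
compound 3, `COC(=O)C1=C(C)NC(C)=C(C(=O)OCc2ccco2)C1c1cccc([N+](=O)[O-])c1`, 20 nM

All three numbers come from a functional assay on HEK293 cells for antagonist activity at Voltage-dependent L-type calcium channel subunit alpha-1C (Oryctolagus cuniculus), read by FLIPR; on this read-out lower numbers stand for stronger inhibition and higher numbers for weaker inhibition. Compound 3 stands second highest of the three; its nearest neighbour is compound 2, with a 1.3-fold higher number from compound 2 to compound 3 (0.10 log units; within the scatter), and its furthest is compound 1, with a 1.3-fold lower number from compound 1 to compound 3 (0.11 log units; within the scatter), both within the scatter. Compound 4, `COC(=O)C1=C(C)NC(C)=C(C(=O)OCCOc2ccccc2Cl)C1c1cccc([N+](=O)[O-])c1`, has not yet been measured in this assay. It differs from compound 3 by (2-chlorophenoxy)methyl in place of furan-2-yl on a saturated chain carbon bound to an oxygen next to a carbonyl group.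

Among the compounds with values here, the steps that bear on this change all alter the same position: a 1.6-fold lower number from compound 1 to compound 2 (0.21 log units; within the scatter), a 1.3-fold lower number from compound 1 to compound 3 (0.11 log units; within the scatter) and a 1.3-fold higher number from compound 2 to compound 3 (0.10 log units; within the scatter). None of them left the scatter, so groups of rather different shape at this position gave numbers that cannot be told apart. On this basis no step beyond the scatter is expected for compound 4 in this assay, in either direction. Compound 4 is therefore estimated at 20 nM, within a range of 8 nM to 50 nM, which corresponds to an expected no change at the digits printed from compound 3 to compound 4 (within the scatter).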

Compound 4, half-maximal inhibitory concentration: 19 nM
The estimate for compound 4 lay 1.1-fold (0.02 log units) above the measured number, and the stated range covers the measured number.
By their numbers in this assay, from the lowest: compounds 2, 4, 3 and 1 (each within the scatter of the next).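

The earlier compounds shown here carried nothing as long as 2-(2-chlorophenoxy)ethyl at this position, yet in this assay this change gave a 1.1-fold lower number from compound 3 to compound 4 (0.02 log units; within the scatter). The other two steps, a 1.2-fold higher number from compound 2 to compound 4 (0.07 log units; within the scatter) and a 1.4-fold lower number from compound 1 to compound 4 (0.14 log units; within the scatter), also stay within the scatter, so the four compounds cannot be told apart on this read-out, and the tolerance seen so far now extends to a chain that carries a six-membered aromatic ring of carbon only. No evidence at hand accounts for these numbers staying together.

From the compounds shown here alone, it stays open whether a side chain ending in an amine or a carboxylic acid would remain within the scatter of these four compounds. Also open, going by these compounds, is what a plain phenoxy group would give in place of 2-chlorophenoxy.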